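From acetylpyrrolidine to methylpiperazine on a shared core

A few compounds are considered here, and "the series" means these few. Any claim that something is new, unique, unknown or untested is made for them only; others in the source may bear on it.

Measured values in an in vivo ADME assay on the whole organism for metabolic stability, with Rattus norvegicus as the target (a higher number here means that the compound lasts longer, a lower number that the compound disappears faster), follow
- Compound 1 `CC(=O)Nc1ccc(Nc2nc(N)n(-c3ccccn3)n2)cc1` gives 1.33 h
- Compound 2 `CC(=O)N1CCC(c2ccc(Nc3nc(N)n(-c4ccccn4)n3)cc2)C1` gives 1.42 h

Compound 2 stands within the scatter of compound 1, with neither ahead. Compound 3 `CN1CCN(c2ccc(Nc3nc(N)n(-c4ccccn4)n3)cc2)CC1` differs from compound 2 by 4-methylpiperazin-1-yl in place of 1-acetylpyrrolidin-3-yl on an aromatic carbon on an aromatic carbon. For the measured compounds named here, no measured compound carries 4-methylpiperazin-1-yl. Going by the values given here, the only guide to size is a 1.1-fold higher number from compound 1 to compound 2 (0.03 log units; within the scatter), which came with 1-acetylpyrrolidin-3-yl in place of acetamido on an aromatic carbon. A step no larger than the scatter is therefore expected in this assay, with no direction favoured. The estimated half-life of compound 3 is 1.5 h, with an expected range from 0.7 h to 3.2 h. This estimate means an expected 1.1-fold higher number from compound 2 to compound 3 (0.02 log units; within the scatter).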

Compound 3, half-life: 2.54 h
Compound 3: the middle estimate sits 1.7-fold (0.23 log units) below what was measured, within the range that was stated.
By their numbers in this assay, from the lowest: compounds 1, 2 and 3 (each within the scatter of the next).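

In this assay, 4-methylpiperazin-1-yl on an aromatic carbon, para to a large group, stays within the scatter of both earlier groups: in place of 1-acetylpyrrolidin-3-yl it gives a 1.8-fold higher number from compound 2 to compound 3 (0.25 log units; within the scatter), and in place of acetamido it gives a 1.9-fold higher number from compound 1 to compound 3 (0.28 log units; within the scatter). The half-life at this position is thus shown to hold with a six-membered ring with 2 hetero atoms and no carbonyl. Nothing available explains the result. On these data alone, whether an open-chain amine or a carboxylic acid here would move the half-life beyond the scatter remains open.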